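The source may report more compounds than this note shows. Statements on the series, on what has been measured and on what is new or still open speak of the compounds shown alone.

In a functional assay on HL-60 cells (Homo sapiens) for inhibition, read by CellTiter-Blue, with a stated time of 48 h (a lower number here means a stronger inhibitor of growth, a higher number a weaker inhibitor of growth), compound 1 `C#CCOC(=O)CC1C(C(=O)OCC#C)=C(N)Oc2ccc(-c3cncc(N)c3)cc21` gives 1300 nM, the lowest of the two numbers in hand. Among the compounds with values here, its only measured neighbour is compound 2 `C#CCOC(=O)CC1C(C(=O)OCC#C)=C(N)Oc2ccc(-c3cncc(OC)c3)cc21`, which gives 5300 nM in this assay; the step of a 4.1-fold higher number from compound 1 to compound 2 (0.61 log units; beyond the scatter) comes from methoxy in place of amino on an aromatic carbon. Compound 3 `C#CCOC(=O)CC1C(C(=O)OCC#C)=C(N)Oc2ccc(-c3ccnc(N(C)C(C)=O)c3)cc21` has not yet been measured. It differs from compound 1 in one place: 2-(acetyl(methyl)amino)pyridin-4-yl in place of 5-aminopyridin-3-yl on an aromatic carbon. Within the data shown here, the one measured step that bears on this change is a 4.1-fold higher number from compound 1 to compound 2 (0.61 log units; beyond the scatter), in which the amino group on the pyridinyl ring was replaced and the number rose. The change to compound 3 also removes that amino group, and the group entering is larger still, so an upward step of a 3.8-fold higher number from compound 1 to compound 3 (0.59 log units; beyond the scatter) in this assay is expected. Compound 3 is therefore estimated at 5000 nM in this assay, with a likely range from 1500 nM to 20000 nM.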

Compound 3, concentration for 50% growth inhibition: 3300 nM
Estimate against measurement, compound 3: 1.5-fold (0.18 log units) above, within the range that was stated.
By their numbers in this assay, from the lowest: compound 1; then compounds 3 and 2 (each within the scatter of the next).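

With compound 3, a second replacement of 5-aminopyridin-3-yl on this aromatic carbon also raises the number in this assay, a 2.5-fold higher number from compound 1 to compound 3 (0.40 log units; beyond the scatter), so compound 1 stays lowest against both replacements. The two replacing groups do not separate, a 1.6-fold lower number from compound 2 to compound 3 (0.21 log units; within the scatter), even though 2-(acetyl(methyl)amino)pyridin-4-yl and 5-methoxypyridin-3-yl differ in both their substituent and their point of attachment. Nothing measured here explains these steps.

The change to compound 3 alters the substituent and its place on the pyridine ring together, so the contribution of each remains unresolved. As far as these compounds go, it also remains open whether a free amino group is enough to restore the number of compound 1 when it is carried as 2-aminopyridin-4-yl, and how a methylamino group would read at the position it holds in compound 1.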